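Permeability across a change on the biaryl end

A few compounds are considered here, and "the series" means these few. Any claim that something is new, unique, unknown or untested is made for them only; others in the source may bear on it.

Compound 1, `COc1cccc(CNCCCNc2ccnc3cc(-c4ccc(C(C)(C)C)cc4)ccc23)c1O`: 237 10^-6 cm/s
Compound 2, `COc1ccc(-c2ccc3c(NCCCNCc4cc(F)ccc4OC)ccnc3c2)cc1`: 237 10^-6 cm/s

Of the compounds shown here, two have been measured in an ADME assay for permeability, using PAMPA, with a stated time of 30 min, at pH 7.4; on this read-out higher numbers stand for higher permeability and lower numbers for lower permeability. Compound 1 gives 237 10^-6 cm/s in this assay, and compound 2 gives 237 10^-6 cm/s. The two readings are level at the digits shown and lie within the usual scatter of each other, so on the numbers alone nothing sets one apart from the other. Compound 2 therefore stands level with compound 1, its nearest neighbour among the measured compounds.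

The step now followed goes from compound 2 to compound 3, `COc1ccc(F)cc1CNCCCNc1ccnc2cc(-c3ccc(C(C)(C)C)cc3)ccc12`. The change is tert-butyl in place of methoxy on an aromatic carbon. Cut one bond further out, the same difference reads 4-methoxyphenyl to 4-(tert-butyl)phenyl. Compound 1, which itself carries a 4-(tert-butyl)phenyl group, gives 237 10^-6 cm/s, a reading no different from that of compound 2 at the digits shown.

Among the measured compounds shown here, no step between measured compounds is available for this change. Given that compound 2 reads level, at the digits shown, with compound 1 at 237 10^-6 cm/s, the step from compound 2 to compound 3 in this assay is expected to be none beyond the scatter, no change at the digits printed from compound 2 to compound 3 (within the scatter). Compound 3 is accordingly estimated at 237 10^-6 cm/s, within a range of 150 10^-6 cm/s to 320 10^-6 cm/s.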

Compound 3, apparent permeability: 237 10^-6 cm/s
Compound 3: the middle estimate sits on the measured number at the digits printed; the measured number falls inside the stated range.
By their numbers in this assay, from the lowest: compounds 1, 2 and 3 (each within the scatter of the next).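

In this assay, tert-butyl in place of methoxy on an aromatic carbon, para to a large group, gives no change at the digits printed from compound 2 to compound 3 (within the scatter) and so adds a direct reading for this change, which until now had rested only on the level values of two compounds differing in more than one place. Compound 3 also links compound 1 to this series through a single change, since 5-fluoro-2-methoxyphenyl in place of 2-hydroxy-3-methoxyphenyl on a saturated chain carbon bound to an amine nitrogen gives no change at the digits printed from compound 1 to compound 3 (within the scatter) with the 4-(tert-butyl)phenyl group held the same. Nothing to hand explains why either change leaves the reading level.

What the compounds shown leave open is whether this level reading would hold for a very different group at the same aromatic carbon, such as a carboxylic acid or a primary amine in place of tert-butyl. They also leave open whether a longer chain in place of the saturated chain bound to the amine nitrogen would move the value in this assay beyond the scatter.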